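The compounds below may be only part of what the source reports. "The series", "measured", "known", "first", "only" and "open" are said of these compounds alone.

Measured so far in a functional assay on BGC-823 cells (Homo sapiens) for cytotoxicity, read by MTT assay, with a stated time of 72 h; on this read-out lower numbers stand for stronger inhibition and higher numbers for weaker inhibition:
- compound 1 `CN1[C@@H]2c3[nH]c4ccccc4c3C[C@H]1[C@H](C#N)N1[C@@H](CN3C(=O)c4ccccc4C3=O)c3[nH]c4ccccc4c3C[C@@H]21`: 410 nM
- compound 2 `CN1[C@@H]2c3[nH]c4ccccc4c3C[C@H]1[C@H](C#N)N1[C@@H](CNC(=O)c3cccc(C(F)(F)F)c3)c3[nH]c4ccccc4c3C[C@@H]21`: 870 nM
- compound 3 `CN1[C@@H]2c3[nH]c4ccccc4c3C[C@H]1[C@H](C#N)N1[C@@H](CNC(=O)c3ccc(F)cc3)c3[nH]c4ccccc4c3C[C@@H]21`: 310 nM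

Compound 3 holds the lowest of these three numbers. One gap is small (a 1.3-fold lower number from compound 1 to compound 3 (0.12 log units; within the scatter)), while the step from compound 2 is larger (a 2.8-fold lower number from compound 2 to compound 3 (0.45 log units; beyond the scatter)). Compound 4 `CN1[C@@H]2c3[nH]c4ccccc4c3C[C@H]1[C@H](C#N)N1[C@@H](CNC(=O)c3ccc4ccccc4c3)c3[nH]c4ccccc4c3C[C@@H]21` changes the same position once more: naphthalen-2-yl in place of 4-fluorophenyl on a carbonyl carbon. Within the data shown here, only the step from compound 2 to compound 3 bears on this, and it shows that exchanging one aromatic group on the carbonyl for another moved this assay modestly. Among the measured compounds shown here, no measured compound carries a naphthalen-2-yl group, so the direction is open. A modest step at most is expected, a 1.5-fold higher number from compound 3 to compound 4 (0.16 log units; within the scatter). Compound 4 is therefore estimated at 450 nM, within 150 nM to 1300 nM.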

Compound 4, half-maximal inhibitory concentration: 1110 nM
Estimate against measurement, compound 4: 2.5-fold (0.39 log units) below; measured number inside the range.
By their numbers in this assay, from the lowest: compounds 3 and 1 (each within the scatter of the next); then compounds 2 and 4 (each within the scatter of the next).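

On the carbonyl carbon, the choice of aromatic group clearly matters in this assay: two-ring naphthalen-2-yl in place of 4-fluorophenyl gives a weaker result (a 3.6-fold higher number from compound 3 to compound 4 (0.55 log units; beyond the scatter)). Naphthalen-2-yl and 3-(trifluoromethyl)phenyl cannot be told apart (a 1.3-fold higher number from compound 2 to compound 4 (0.11 log units; within the scatter)), so among these three amides, compound 3 alone stands apart. No measurement shown explains this difference. On these data alone, whether unsubstituted phenyl, a pyridine ring or a saturated cyclohexyl group on the carbonyl would match 4-fluorophenyl remains open.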